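The compounds below may be only part of what the source reports. "The series", "measured", "known", "first", "only" and "open" are said of these compounds alone.

Measured compounds in an assay on isolated protein for inhibition of Polyunsaturated fatty acid 5-lipoxygenase (Homo sapiens); a lower number here means a stronger inhibitor, a higher number a weaker inhibitor: compound 1 `CCc1cccc(N2CCCC(=O)N2)c1` gives 3000 nM; compound 2 `CC(C)(C)C(=O)c1cccc(N2CCCC(=O)N2)c1` gives 15000 nM.

For the measured compounds named here, compound 2 stands at the higher of the two numbers; its only neighbour is compound 1, and the step of a 5.0-fold higher number from compound 1 to compound 2 (0.70 log units; beyond the scatter) lies beyond the scatter. Going by the values given here, that step, (tert-butyl)carbonyl in place of ethyl on an aromatic carbon, is the one comparison in hand for changes at this position of the shared core.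

Compound 3 `N#Cc1cccc(N2CCCC(=O)N2)c1` is not yet measured. The change from compound 2 is cyano in place of (tert-butyl)carbonyl on an aromatic carbon. Among the compounds with values here, no measured pair shows cyano at this position, so the expectation rests on the single step from compound 1 to compound 2: the larger group gave the higher number, and its removal is expected to bring the number back toward that of compound 1. The step from compound 2 to compound 3 is therefore expected to be a 3.0-fold lower number from compound 2 to compound 3 (0.48 log units; beyond the scatter), a modest lowering. Compound 3 is expected to give 5000 nM in this assay, with a range of 1500 nM to 20000 nM.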

Compound 3, half-maximal inhibitory concentration: 9300 nM
Compound 3: middle estimate off by 1.9-fold (0.27 log units), on the low side; the measured number falls inside the stated range.
By their numbers in this assay, from the lowest: compound 1; then compounds 3 and 2 (each within the scatter of the next).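

In this assay the step of a 1.6-fold lower number from compound 2 to compound 3 (0.21 log units; within the scatter) stays within the scatter, so going from the 6 heavy atoms of (tert-butyl)carbonyl to the 2 of cyano does not separate the two compounds. The step of a 3.1-fold higher number from compound 1 to compound 3 (0.49 log units; beyond the scatter) lies beyond the scatter, so ethyl still gives the lowest number at this position, and the heavy-atom count of the group alone does not order the three compounds. No measurement in hand explains the differences among these groups.

The compounds shown leave open whether a longer alkyl chain such as propyl, or a group of another kind such as an amine or a carboxylic acid, would match ethyl or improve on it at this position. They also leave open how these groups behave elsewhere on the aromatic ring.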